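The source may report more compounds than this note shows. Statements on the series, on what has been measured and on what is new or still open speak of the compounds shown alone.

Compound 1 `CC(O)(CSc1cccc(C(F)(F)F)c1)C(=O)Nc1cccc(S(F)(F)(F)(F)F)c1` gives 19100 nM
Compound 2 `CC(O)(CSc1ccccc1C(F)(F)F)C(=O)Nc1cccc(S(F)(F)(F)(F)F)c1` gives 15800 nM

In a functional assay on DU-145 cells (Homo sapiens) for antiproliferative activity, read by propidium iodide staining, with a stated time of 96 h (on this read-out higher numbers stand for weaker inhibition and lower numbers for stronger inhibition), compound 2 stands at 15800 nM and lies within the scatter of compound 1 at 19100 nM with no other number to compare. Compound 3 `CC(O)(CSc1ccccc1OC(F)(F)F)C(=O)Nc1cccc(S(F)(F)(F)(F)F)c1` differs from compound 2 in one group: trifluoromethoxy in place of trifluoromethyl on an aromatic carbon with trifluoromethoxy in place of trifluoromethyl on an aromatic carbon, ortho to a large group. Among the compounds with values here, the one measured step of a 1.2-fold lower number from compound 1 to compound 2 (0.08 log units; within the scatter) stays within the scatter and concerns a different change, and no measured step tests trifluoromethoxy. No shift beyond the scatter is therefore expected in this assay for this change. The expected step is a 1.1-fold lower number from compound 2 to compound 3 (0.02 log units; within the scatter) and lies within the scatter. Compound 3 is estimated at 15000 nM with a range of 7000 nM to 32000 nM.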

Compound 3, half-maximal inhibitory concentration: 17500 nM
Beside the measured number, compound 3's estimate is 1.2-fold (0.07 log units) below it; low and high end bracket the measured number.
By their numbers in this assay, from the lowest: compounds 2, 3 and 1 (each within the scatter of the next).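

In this assay, trifluoromethoxy in place of trifluoromethyl on this aromatic carbon, ortho to a large group, gives a 1.1-fold higher number from compound 2 to compound 3 (0.04 log units; within the scatter) and the two groups are not told apart. Within the data shown here, the earlier compounds compared only placements of trifluoromethyl, so this is the first reading of a different group here, one that adds a hydrogen-bond acceptor by count. No measured evidence bears on this result. On these data alone, whether an amine or a carboxylic acid on this carbon would separate from trifluoromethyl stays open, as does whether the same exchange reads alike elsewhere on the ring.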